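A few compounds are considered here, and "the series" means these few. Any claim that something is new, unique, unknown or untested is made for them only; others in the source may bear on it.

Compound 1 `COc1cc(-c2nccn3cc(-c4ccc(N)cc4)nc23)cc(OC)c1OC` gives 252 nM in a functional assay on HepG2 cells (Homo sapiens) for inhibition, read by MTT assay, with a stated time of 48 h; on this read-out lower numbers stand for stronger inhibition and higher numbers for weaker inhibition.
Compound 2 `COc1cc(-c2nccn3cc(-c4ccc(F)cc4)nc23)cc(OC)c1OC` gives 217 nM.
Compound 3 `COc1cc(-c2nccn3cc(-c4ccc(Cl)cc4)nc23)cc(OC)c1OC` gives 475 nM.

Of these three numbers, that of compound 3 is the highest, though its separation from compound 1 is a 1.9-fold higher number from compound 1 to compound 3 (0.28 log units; within the scatter) and from compound 2 is a 2.2-fold higher number from compound 2 to compound 3 (0.34 log units; beyond the scatter). Compound 4 `COc1cc(-c2nccn3cc(-c4ccc(O)cc4)nc23)cc(OC)c1OC` differs from compound 3 by hydroxy in place of chloro on an aromatic carbon. Both measured steps bear on this change, each placing chloro on the same aromatic carbon in place of another group, and both run toward a higher number, one only modestly and beyond the scatter. Reversing that direction, with hydroxy bringing a donor and an acceptor as amino did in compound 1, a modest fall is expected. Compound 4 is therefore estimated at 260 nM, within 120 nM to 550 nM, a step of a 1.8-fold lower number from compound 3 to compound 4 (0.26 log units; within the scatter).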

Compound 4, half-maximal inhibitory concentration: 823 nM
Estimate against measurement, compound 4: 3.2-fold (0.50 log units) below; the measured number lies above the stated range.
By their numbers in this assay, from the lowest: compounds 2, 1, 3 and 4 (each within the scatter of the next, the first and the last beyond it).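

In this assay, hydroxy on this aromatic carbon does not stand with amino, giving a 3.3-fold higher number from compound 1 to compound 4 (0.51 log units; beyond the scatter), and it also parts from fluoro, giving a 3.8-fold higher number from compound 2 to compound 4 (0.58 log units; beyond the scatter). Against chloro it is not separated, at a 1.7-fold higher number from compound 3 to compound 4 (0.24 log units; within the scatter), so hydroxy falls with chloro at this position rather than with amino. No measurement offered here accounts for this difference between hydroxy and amino. The compounds shown leave open whether methoxy on the same carbon would stand with hydroxy or with fluoro, and how a carboxylic acid there would read.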